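Tryptophan dioxygenase inhibitors: amino for trifluoromethyl

A few compounds are considered here, and "the series" means these few. Any claim that something is new, unique, unknown or untested is made for them only; others in the source may bear on it.

Measured so far:
compound 1 `O=C1NCc2c(NCc3ccccc3[N+](=O)[O-])cccc21`, > 100000 nM (a limit)
compound 2 `FC(F)(F)c1cc(NCc2cccc3sccc23)c2cn[nH]c2c1`, > 100000 nM (a limit)
compound 3 `FC(F)(F)c1cccc(CNc2cc(C(F)(F)F)cc3[nH]ncc23)c1`, 12200 nM

Going by the values given here, in an assay for inhibition of Tryptophan 2,3-dioxygenase (Homo sapiens), with stated times of 10 min and 60 min (on this read-out lower numbers stand for stronger inhibition and higher numbers for weaker inhibition), compound 3 gives 12200 nM, the only number in the set. For compound 1 the value > 100000 nM is a limit of this assay, not a number. For compound 2 the value > 100000 nM is likewise a limit. So compound 3 stands apart from the limit of > 100000 nM in this assay, at which 2 of the 3 values shown sit.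

Compound 4 `Nc1cccc(CNc2cc(C(F)(F)F)cc3[nH]ncc23)c1` differs from compound 3 by amino in place of trifluoromethyl on an aromatic carbon. Among the compounds with values here, no measured pair shows this change, so the step from compound 3 to compound 4 is expected to be a 1.6-fold higher number from compound 3 to compound 4 (0.21 log units; within the scatter), modestly toward weaker inhibition and possibly within the scatter. Compound 4 is therefore estimated at 20000 nM, with a range from 5000 nM to 100000 nM in this assay.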

Compound 4, half-maximal inhibitory concentration: 2510 nM
For compound 4 the middle estimate is 8.0-fold (0.90 log units) above the measured one; the whole stated range lies above it.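

In this assay, amino in place of trifluoromethyl on an aromatic carbon gives a 4.9-fold lower number from compound 3 to compound 4 (0.69 log units; beyond the scatter) in the only single-place comparison shown. The substituent at this place, meta to a large group, therefore moves the read-out, and trifluoromethyl is not required there for a measurable value. Compound 1 and compound 2 each remain at a limit of the assay, not a number: the limit of > 100000 nM in this assay, at which 2 of the 4 values shown sit.

As far as these compounds go, whether the shift comes from amino itself or from the loss of trifluoromethyl stays open. Hydrogen, hydroxyl or aminomethyl at this place would bear on that.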